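From 2-chlorophenyl to 4-methylphenyl: what to expect

This account rests on a few compounds, and the source may have more. Where it says the series, first, only, none or still open, it means among the compounds named here.

- compound 1 `CC1(C)[C@H]2CC[C@]1(C)N(Cc1cn(-c3ccc(C#N)cc3)nn1)C(=O)C2`: 140 nM
- compound 2 `CC1(C)[C@H]2CC[C@]1(C)N(Cc1cn(-c3ccc(F)cc3)nn1)C(=O)C2`: 230 nM
- compound 3 `CC1(C)[C@H]2CC[C@]1(C)N(Cc1cn(-c3ccccc3Cl)nn1)C(=O)C2`: 70 nM

All three compounds share one core and differ only in the substituted phenyl group. They were tested in a functional assay on A549 cells (Homo sapiens) for inhibition, read by MTT assay, with a stated time of 24 h (on this read-out lower numbers stand for stronger inhibition and higher numbers for weaker inhibition), where compound 3 gives 70 nM and sits at the low end of the three numbers. It is clearly apart only from compound 2, since a 3.3-fold lower number from compound 2 to compound 3 (0.52 log units; beyond the scatter), while a 2.0-fold lower number from compound 1 to compound 3 (0.30 log units; within the scatter).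

Compound 4 `Cc1ccc(-n2cc(CN3C(=O)C[C@@H]4CC[C@@]3(C)C4(C)C)nn2)cc1` has not been measured. It carries 4-methylphenyl in place of 2-chlorophenyl on an aromatic nitrogen. The two steps above bear most closely on this change, as each one replaces a 4-substituted phenyl group with 2-chlorophenyl. Read backwards, they point to a higher number on leaving 2-chlorophenyl, although no 4-methylphenyl compound has yet been tested. The expected change is a 2.3-fold higher number from compound 3 to compound 4 (0.36 log units; beyond the scatter), similar in size to those two steps. For compound 4 the estimate is 160 nM, with an expected range from 75 nM to 340 nM.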

Compound 4, half-maximal inhibitory concentration: 400 nM
Beside the measured number, compound 4's estimate is 2.5-fold (0.40 log units) below it; the whole stated range lies below it.
By their numbers in this assay, from the lowest: compounds 3, 1, 2 and 4 (each within the scatter of the next, the first and the last beyond it).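

In this assay, replacing 2-chlorophenyl with 4-methylphenyl gives the largest step in this small set, a 5.7-fold higher number from compound 3 to compound 4 (0.76 log units; beyond the scatter), so compound 3 now stands clearly apart from a second 4-substituted phenyl compound. The group on that ring carbon can also matter beyond the scatter, as methyl in place of cyano gives a 2.9-fold higher number from compound 1 to compound 4 (0.46 log units; beyond the scatter), whereas methyl in place of fluoro gives a 1.7-fold higher number from compound 2 to compound 4 (0.24 log units; within the scatter) and cannot be separated from noise. Nothing measured here explains why these groups differ.

The step from compound 3 to compound 4 changes both the substituent and where it sits, and these two changes cannot be separated without a phenyl group carrying chlorine where compound 4 has methyl, or methyl where compound 3 has chlorine. On these data alone, how an amine or a carboxylic acid on the phenyl ring would behave also remains open.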